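Swapping a Sulfur-Bearing Side Chain for a Cyanophenyl Group

The compounds below may be only part of what the source reports. "The series", "measured", "known", "first", "only" and "open" are said of these compounds alone.

Measured compounds:
Compound 1 `Nc1nc(O)c2c(n1)n(C1OC(CO)[C@@H](O)[C@H]1O)c(=O)n2CC(O)CSc1ccccc1` gives 12% in a functional assay on the whole organism (B cells) with Mus musculus as the target; a higher number here means a larger maximal response, a lower number a smaller maximal response.
Compound 2 `C=CCn1c(=O)n(C2OC(CO[Si](C)(C)C(C)(C)C)[C@@H](O)[C@H]2O)c2nc(N)nc(O)c21` gives 5% in this assay.
Compound 3 `C=CCn1c(=O)n([C@H]2CO[C@@H](CO)C2)c2nc(N)nc(O)c21` gives 10% in this assay.

Compound 1 carries the nominally highest of the three numbers, but compound 3 and compound 2 both lie within the usual scatter of it, so the three compounds cannot be told apart on these data. All three sit far below the reference.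

Compound 4 `N#Cc1cccc(Cn2c(=O)n(C3OC(CO)[C@@H](O)[C@H]3O)c3nc(N)nc(O)c32)c1` differs from compound 1 in one place: 3-cyanophenyl in place of 1-hydroxy-2-(phenylsulfanyl)ethyl on a saturated chain carbon bound to an aromatic nitrogen

For the measured compounds named here, no measured pair here shows what such a change does in this assay, so the step from compound 1 to compound 4 is expected to stay within the scatter, with no clear direction: a number 2 percentage points lower from compound 1 to compound 4 (within the scatter). Compound 4 is therefore expected to give about 10%, most likely between 2% and 25%.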

Compound 4, largest response reached (reported as maximal response), in percent of the reference or control that the assay uses: 16%
Estimate against measurement, compound 4: 6 percentage points below, within the range that was stated.
By their numbers in this assay, from the lowest: compounds 2, 3, 1 and 4 (each within the scatter of the next, the first and the last beyond it).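

For the compounds shown here, this is the first step that can be read at this position: 3-cyanophenyl in place of 1-hydroxy-2-(phenylsulfanyl)ethyl on a saturated chain carbon bound to an aromatic nitrogen gives a number 4 percentage points higher from compound 1 to compound 4 (within the scatter) in this assay. The hydroxyl and the sulfur of the old side chain can therefore be lost without a clear drop in response. Nothing available explains this result.

On these data alone, it remains open whether any group here can move the number beyond the scatter, such as a carboxylic acid in place of the nitrile or a longer chain ending in an amine.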